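Pyrimidin-5-yl for pyridin-3-yl: a change at the limit

A few compounds are considered here, and "the series" means these few. Any claim that something is new, unique, unknown or untested is made for them only; others in the source may bear on it.

Measured so far:
compound 1, `Cc1cc(Cl)nnc1N1CCN(c2ncccn2)CC1`, > 100000 nM
compound 2, `Cc1cc(-c2cccnc2)nnc1N1CCN(c2ncccn2)CC1`, > 100000 nM

In a functional assay on BV-2 cells (Mus musculus) for inhibition, read by ELISA, with a stated time of 16 h (a lower number here means a stronger inhibitor, a higher number a weaker inhibitor), compound 1 gives only the limit of the assay, > 100000 nM. Compound 2 likewise gives only the limit, > 100000 nM. The step that the two limits leave unreadable from compound 1 to compound 2 is therefore unreadable, and compound 2 stands at the limit of > 100000 nM in this assay, at which 2 of the 2 values shown sit, with no number to place it more finely.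

Compound 3, `Cc1cc(-c2cncnc2)nnc1N1CCN(c2ncccn2)CC1`, is not yet measured. It differs from compound 2 by pyrimidin-5-yl in place of pyridin-3-yl on an aromatic carbon. Among the compounds with values here, the only measured step, a step that the two limits leave unreadable from compound 1 to compound 2, bears on a change at the same position but cannot be read; no step involving a pyrimidin-5-yl is known. With compound 2 at the limit, the expectation for compound 3 is that it also stays at the limit, so the step of a number no higher from compound 2 to compound 3 (the limit leaves the size open) is expected to be none readable. Compound 3 is thus estimated at 100000 nM, between 30000 nM and 300000 nM.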

Compound 3, half-maximal inhibitory concentration: > 100000 nM
Compound 3: a limit, no number (the forecaster's own chance of this, stated with the estimate: 85%); the middle value sits exactly at the limit.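

Compound 3 gives only a limit, as do compound 1 and compound 2, so no step among the three can be read in this assay: the limit of > 100000 nM in this assay, at which 3 of the 3 values shown sit.

The compounds shown leave open how the three compare and whether any group at this position gives a measurable inhibition.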